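Chloro to bromo on the phenyl group of compound 3

The compounds below may be only part of what the source reports. "The series", "measured", "known", "first", "only" and "open" are said of these compounds alone.

Read in a functional assay on MCF7 cells (Homo sapiens) for cytotoxicity, read by MTT assay, with a stated time of 96 h (on this read-out higher numbers stand for weaker inhibition and lower numbers for stronger inhibition), these compounds give:
compound 1 `COc1cc(C(=O)c2cn(-c3ccccc3[N+](=O)[O-])cc2-c2ccccc2)cc(OC)c1OC`: 5000 nM
compound 2 `COc1cc(C(=O)c2cn(-c3ccccc3N)cc2-c2ccccc2)cc(OC)c1OC`: 3800 nM
compound 3 `COc1cc(C(=O)c2cn(-c3ccc(Cl)cc3)cc2-c2ccccc2)cc(OC)c1OC`: 140 nM

Compound 3 has the lowest of the three numbers in this assay and its distance to both others lies beyond the scatter. The two large steps leading to it are a 36-fold lower number from compound 1 to compound 3 (1.55 log units; beyond the scatter) and a 27-fold lower number from compound 2 to compound 3 (1.43 log units; beyond the scatter) and each puts 4-chlorophenyl in place of another substituted phenyl on an aromatic nitrogen. The remaining step, a 1.3-fold lower number from compound 1 to compound 2 (0.12 log units; within the scatter), lies within the scatter. Compound 4 `COc1cc(C(=O)c2cn(-c3ccc(Br)cc3)cc2-c2ccccc2)cc(OC)c1OC` differs from compound 3 in one place only, by bromo in place of chloro on an aromatic carbon and this is bromo in place of chloro on an aromatic carbon, para to a large group. Going by the values given here, no measured step exchanges one halogen for another, so the large steps bear on it only indirectly. The 4-bromophenyl group keeps the substituent in the same place, so the expected step is a 1.1-fold higher number from compound 3 to compound 4 (0.03 log units; within the scatter) and it is not expected to go beyond the scatter. Compound 4 is estimated at 150 nM with an expected range of 60 nM to 400 nM.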

Compound 4, half-maximal inhibitory concentration: 20 nM
Beside the measured number, compound 4's estimate is 7.5-fold (0.88 log units) above it; measured number below the stated range.
By their numbers in this assay, from the lowest: compound 4; then compound 3; then compounds 2 and 1 (each within the scatter of the next).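

In this assay bromo in place of chloro on an aromatic carbon gives a 7.0-fold lower number from compound 3 to compound 4 (0.85 log units; beyond the scatter) and so shows that this position responds to an exchange of one halogen for another, with one heavy atom leaving and one entering and no ring, hydrogen-bond donor or acceptor, or net charge involved. The earlier compounds shown here had compared 4-chlorophenyl only with 2-nitrophenyl and 2-aminophenyl, whereas 4-bromophenyl now gives a 190-fold lower number from compound 2 to compound 4 (2.28 log units; beyond the scatter) and a 250-fold lower number from compound 1 to compound 4 (2.40 log units; beyond the scatter) as wider steps from those two groups. Nothing measured here explains why bromo gives the lower number.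

Going by these compounds, whether iodo, methyl or methoxy on the same aromatic carbon would continue or reverse this step stays open. So does whether the step between compound 3 and compound 4 holds in other cell lines.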